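Swapping a methyl for two chlorines on a weak scaffold

The source may report more compounds than this note shows. Statements on the series, on what has been measured and on what is new or still open speak of the compounds shown alone.

Compound 3 `C=CCn1c(=O)/c(=C\c2ccc(C)cc2)[nH]c(=O)/c1=C\c1ccccc1OC` was tested in a functional assay on A549 cells (Homo sapiens) for cytotoxicity, read by CCK-8 assay, with a stated time of 72 h (on this read-out lower numbers stand for stronger inhibition and higher numbers for weaker inhibition), and came out as "not active" (no number reported), so no number stands for it. Compound 2 `C=CCn1c(=O)/c(=C\c2ccc(Cl)c(Cl)c2)[nH]c(=O)/c1=C\c1ccccc1` likewise gives "not active" (no number reported). Only compound 1 `C=CCn1c(=O)/c(=C\c2cccc(C)c2)[nH]c(=O)/c1=C\c1ccccc1OC` gives a number, 22700 nM, and that is a weak result. Compound 4 `C=CCn1c(=O)/c(=C\c2ccc(Cl)c(Cl)c2)[nH]c(=O)/c1=C\c1ccccc1OC` has not yet been measured. The change from compound 3 is 3,4-dichlorophenyl in place of 4-methylphenyl on a double-bonded chain carbon bound to an aromatic carbon. Going by the values given here, no step between measured compounds is available, so the size of this step in this assay cannot be read off directly; with compound 2 carrying the same 3,4-dichlorophenyl and giving "not active" (no number reported), a weaker outcome or none beyond the scatter is expected rather than a gain. Compound 4 is expected to give about 45000 nM, within 15000 nM to 120000 nM, and quite possibly only a report of no activity.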

Compound 4, half-maximal inhibitory concentration: "not active" (no number reported)
The entry for compound 4 holds no number, and the estimate cannot be compared.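

Compound 3 and compound 4 are both reported as not active, with no number, so no step can be read between them. Nothing measured here offers an explanation. Going by these compounds, whether 3,4-dichlorophenyl in place of 4-methylphenyl changes potency at all stays open.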